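Three Cytotoxicity Limits and a Fourth Analogue

This account rests on a few compounds, and the source may have more. Where it says the series, first, only, none or still open, it means among the compounds named here.

Compound 1 `C=CC1=C(C(=O)Nc2ccccc2OC)C(c2ccc(Cl)c(Cl)c2)OC1`, compound 2 `C=CC1=C(C(=O)NCc2ccc(C)cc2)C(c2ccc(OC)cc2)OC1` and compound 3 `C=CC1=C(C(=O)NCc2ccccc2F)C(c2ccc(OC)cc2)OC1` share one core and differ in the amide substituent and in the aryl group on the ring. In a functional assay on A549 cells (Homo sapiens) for cytotoxicity, read by MTT assay, with a stated time of 24 h (a higher number here means a weaker inhibitor, a lower number a stronger inhibitor), compound 1 reaches only the limit of the assay, > 100000 nM. In this assay compound 2 likewise gives only a limit, > 100000 nM. In this assay compound 3 also stays at the limit, > 100000 nM. The change from compound 2 to compound 3 is a step that the two limits leave unreadable from compound 2 to compound 3, because both values sit at the limit of > 100000 nM in this assay, at which 3 of the 3 values shown sit. Compound 3 thus stands at the limit, as do the two other measured values.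

Compound 4 `C=CC1=C(C(=O)Nc2ccccc2OC)C(c2ccc(OC)cc2)OC1` differs from compound 3 by 2-methoxyphenyl in place of 2-fluorobenzyl on an amide-type nitrogen. No measured step reads on this exchange, since the only step shown is unreadable. Compound 1 carries the same 2-methoxyphenyl on the amide nitrogen and gives only the limit > 100000 nM. Compound 4 is accordingly expected to remain at the limit, with an unreadable step a number no higher from compound 3 to compound 4 (the limit leaves the size open). The estimate for compound 4 is 100000 nM, between 50000 nM and 300000 nM.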

Compound 4, half-maximal inhibitory concentration: > 100000 nM
Compound 4: only a limit was reported; the forecaster's own chance of this, stated with the estimate: 90%; the middle value lies on the limit itself.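

In this assay compound 4 gives only a limit, > 100000 nM. The steps from compound 1, compound 2 and compound 3 to compound 4 cannot be read, because all the values sit at one shared limit: the limit of > 100000 nM in this assay, at which 4 of the 4 values shown sit.

The compounds shown leave open whether any amide substituent or aryl group on the shared core would give a measurable value in this assay.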